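Bromo in place of chloro: compound 3 to compound 4

A few compounds are considered here, and "the series" means these few. Any claim that something is new, unique, unknown or untested is made for them only; others in the source may bear on it.

In a functional assay on Bel-7402 cells (Homo sapiens) for inhibition, read by MTT assay, with a stated time of 24 h, tested at 100 ug/mL (a lower number here means less inhibition of growth, a higher number more inhibition of growth at the concentration tested), compound 1 (`O=C(CCCCC1CCSS1)NO`) gives 12.5%, compound 2 (`O=C(CCCCC1CCSS1)Nc1ccccn1`) gives 37.6% and compound 3 (`O=C(CCCCC1CCSS1)Nc1ccc(Cl)cn1`) gives 48.5%. Compound 3 holds the highest of the three numbers, and its gaps to both others lie beyond the scatter.

The next structure is compound 4 (`O=C(CCCCC1CCSS1)Nc1ccc(Br)cn1`), with bromo in place of chloro on an aromatic carbon. The site is two atoms from the ring nitrogen and para to a large group.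

The closest measured precedent is a number 10.9 percentage points higher from compound 2 to compound 3 (beyond the scatter), a modest step beyond the scatter, where a hydrogen of the aromatic ring gives way to chloro. The other measured step, a number 25.1 percentage points higher from compound 1 to compound 2 (beyond the scatter), is also modest and beyond the scatter, but it puts pyridin-2-yl in place of hydroxy on an amide-type nitrogen, so it bears on this change only weakly. Within the data shown here, no measured pair exchanges one halogen for another, so the data show no direct size for this swap. A halogen remains at the same site, so only a small upward move is expected, and no step beyond the scatter. The estimated step is a number 2.5 percentage points higher from compound 3 to compound 4 (within the scatter). For compound 4 the expected value is 51%, with an estimated range from 40% to 62%.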

Compound 4, percent growth inhibition at one concentration: 45.5%
Compound 4: the middle estimate sits 5.5 percentage points above what was measured; the range from low to high includes it.
By their numbers in this assay, from the lowest: compound 1; then compounds 2, 4 and 3 (each within the scatter of the next, the first and the last beyond it).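

In this assay, among these compounds, the exchange of chloro for bromo on this aromatic carbon, para to a large group, gives a number 3 percentage points lower from compound 3 to compound 4 (within the scatter) and is the first comparison of one halogen with another, so at this site the two halogens cannot be told apart. Measured against the parent without a halogen, bromo in place of hydrogen gives a number 7.9 percentage points higher from compound 2 to compound 4 (within the scatter) while chloro in place of hydrogen gives a number 10.9 percentage points higher from compound 2 to compound 3 (beyond the scatter) and so the gain beyond the scatter seen for chloro does not carry over to bromo, which leaves the halogen effect at this carbon less firm than compound 3 alone suggested. Nothing on hand speaks to what lies behind these numbers.

Going by these compounds, whether fluoro or methyl at this carbon would read like chloro and bromo remains open, as does whether an amine or a carboxylic acid there would shift the number beyond the scatter. On these data alone, all of these readings come from one concentration and one exposure time, so how compounds 2, 3 and 4 would separate across a full dose range is also open.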